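This account rests on a few compounds, and the source may have more. Where it says the series, first, only, none or still open, it means among the compounds named here.

Measured so far in a functional assay on A549 cells (Homo sapiens) for antiproliferative activity, read by MTT assay, with a stated time of 24 h; on this read-out lower numbers stand for stronger inhibition and higher numbers for weaker inhibition:
Compound 1 `O=C(NNc1cccc(Cl)c1)c1cccc(NS(=O)(=O)c2cnc(O)nc2O)c1` gives 6640 nM 
Compound 2 `O=C(NNc1ccccc1F)c1cccc(NS(=O)(=O)c2cnc(O)nc2O)c1` gives 11100 nM 

Among the measured compounds shown here, these are the only two numbers available, and compound 2 lies within the scatter of compound 1, so the pair cannot be ranked. Compound 3 `O=C(NNc1ccc(F)cc1)c1cccc(NS(=O)(=O)c2cnc(O)nc2O)c1` keeps the core of compound 2 and differs from it in one group 4-fluorophenyl in place of 2-fluorophenyl on an amine nitrogen in the form of 4-fluorophenyl in place of 2-fluorophenyl on an amine nitrogen. For the measured compounds named here, only one measured step bears on this, a change at that same place: a 1.7-fold higher number from compound 1 to compound 2 (0.22 log units; within the scatter) for 2-fluorophenyl in place of 3-chlorophenyl. Going by the values given here, no measured compound carries the 4-fluorophenyl group, so this evidence is indirect and thin. Because a 1.7-fold higher number from compound 1 to compound 2 (0.22 log units; within the scatter) stayed within the scatter, no move beyond the scatter is expected in this assay in either direction. The estimated step is a 1.2-fold lower number from compound 2 to compound 3 (0.09 log units; within the scatter) and so no clear change is expected. Compound 3 is estimated at 9000 nM with a range from 4000 nM to 20000 nM expected for its measurement.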

Compound 3, half-maximal inhibitory concentration: > 20000 nM
Compound 3 ended at the assay's limit; the forecaster's own chance of this, stated with the estimate: 3%; middle value at least 2.2-fold (0.34 log units) from the limit.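

In this assay compound 3 gives > 20000 nM, which is a limit of the assay and not a number: the limit of > 20000 nM in this assay, at which 1 of the 3 values shown sits. Among the compounds shown here, its comparison with compound 1 gives the first step at this place on the amine nitrogen that lies beyond the scatter, with 4-fluorophenyl in place of 3-chlorophenyl producing an at least 3.0-fold higher number from compound 1 to compound 3 (0.47 log units; beyond the scatter), whereas the earlier change at this place stayed within the scatter. Moving from 2-fluorophenyl to 4-fluorophenyl, with the same atoms joined differently, gives an at least 1.8-fold higher number from compound 2 to compound 3 (0.25 log units; that floor lies within the scatter), so the floor of this step does not separate the two fluorophenyl compounds beyond the scatter.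

Compound 1 and compound 3 differ in both the halogen and its numbered position on the ring, and only 4-chlorophenyl or 3-fluorophenyl on the same amine nitrogen could show which of the two matters. Also open, on these data alone, is how an unsubstituted phenyl or a 4-methoxyphenyl would read in this assay, and whether any group at this place can give a clearly lower number than compound 1.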